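Methyl on a ring nitrogen of compound 3

The source may report more compounds than this note shows. Statements on the series, on what has been measured and on what is new or still open speak of the compounds shown alone.

In a functional assay on a cell-free system (Platelet, plasma, Homo sapiens) for inhibition, read by turbidimetry, with a stated time of 3 min (a lower number here means a stronger inhibitor, a higher number a weaker inhibitor), compound 1 `COc1ccc(-n2nc(C(=O)N3CCCCC3)cc2-c2ccc(Cl)cc2)nn1` gives 41 nM, and compound 2 `COc1ccc(-n2nc(C(=O)Nc3ccncc3)cc2-c2ccc(Cl)cc2)nn1` gives 110 nM. Putting (pyridin-4-yl)amino in place of piperidin-1-yl on a carbonyl carbon accounts for a 2.7-fold higher number from compound 1 to compound 2 (0.43 log units; beyond the scatter), a modest step that lies beyond the scatter.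

Compound 3 `O=C(c1cc(-c2ccc(Cl)cc2)n[nH]1)N1CCOCC1` stands at > 10000 nM, which is a limit of the assay and not a number.

Compound 4 `Cn1nc(-c2ccc(Cl)cc2)cc1C(=O)N1CCOCC1` differs from it in one place, methyl in place of hydrogen on an aromatic nitrogen. Within the data shown here, no measured step changes that nitrogen, so the evidence here is indirect. Among the measured compounds shown here, the only measured step, a 2.7-fold higher number from compound 1 to compound 2 (0.43 log units; beyond the scatter), comes from a change on a carbonyl carbon and is modest in size. That gives no support for expecting a large gain from this one small replacement in this assay, so compound 4 is expected to remain a very weak inhibitor, and another report of only a limit is the likeliest result.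

The expected outcome is a step that the limit leaves unreadable from compound 3 to compound 4, with no clear gain in strength. For compound 4 the estimated value is 15000 nM, within an expected range from 5000 nM to 50000 nM.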

Compound 4, half-maximal inhibitory concentration: > 10000 nM
Compound 4: no number, only a limit; the forecaster's own chance of this, stated with the estimate: 75%; the middle value lies beyond the limit too.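

In this assay compound 4 gives > 10000 nM, which is a limit of the assay and not a number. No step from compound 3 to compound 4 can be read, because compound 3 also stands at a limit: the limit of > 10000 nM in this assay, at which 2 of the 4 values shown sit.

The compounds shown leave open whether methyl in place of hydrogen on an aromatic nitrogen changes the strength of inhibition at all.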